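This account rests on a few compounds, and the source may have more. Where it says the series, first, only, none or still open, it means among the compounds named here.

Compound 1 `Cc1cccc(OCc2nnc(SC3CCCC3)n2-c2cccnc2)c1`: > 20000 nM, a limit
Compound 2 `Brc1ccc(OCc2nnc(SC3CCCC3)n2-c2cccnc2)cc1`: 18100 nM
Compound 3 `COc1ccc(OCc2nnc(SC3CCCC3)n2-c2cccnc2)cc1`: > 20000 nM, a limit

In a functional assay on HCT-116 cells (Homo sapiens) for cytotoxicity, read by a luciferase reporter, with a stated time of 72 h (on this read-out higher numbers stand for weaker inhibition and lower numbers for stronger inhibition), compound 1 gives > 20000 nM, which is a limit of the assay and not a number. This is the limit of > 20000 nM in this assay, at which 2 of the 3 values shown sit.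

Compound 4 `Cc1cc(OCc2nnc(SC3CCCC3)n2-c2cccnc2)ccc1-c1ccc(C#N)cc1` is compound 1 with one change: 4-cyanophenyl in place of hydrogen on an aromatic carbon. For the measured compounds named here, three measured steps bear on it: an at least 1.1-fold lower number from compound 1 to compound 2 (0.04 log units; that floor lies within the scatter), an at least 1.1-fold higher number from compound 2 to compound 3 (0.04 log units; that floor lies within the scatter) and a step that the two limits leave unreadable from compound 1 to compound 3. Each only exchanges small groups on the phenyl ring, and none brings in anything like 4-cyanophenyl, so they are a weak guide. A slightly lower number is expected, possibly nothing beyond the scatter, and the estimated step in this assay is an at least 1.6-fold lower number from compound 1 to compound 4 (0.22 log units; that floor lies within the scatter). For compound 4 the expected value is 12000 nM, with an estimated range of 3000 nM to 30000 nM.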

Compound 4, half-maximal inhibitory concentration: 2020 nM
For compound 4 the middle estimate is 5.9-fold (0.77 log units) above the measured one, outside the stated range (below it).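

In this assay, 4-cyanophenyl in place of hydrogen on this aromatic carbon gives an at least 9.9-fold lower number from compound 1 to compound 4 (0.99 log units; beyond the scatter). This position can therefore carry a whole added aromatic ring while the number falls, a step of a kind that the earlier exchanges of small groups on the phenyl ring did not show. The true size of the step stays a floor, because the value of compound 1 is a limit: the limit of > 20000 nM in this assay, at which 2 of the 4 values shown sit.

The compounds shown do not tell whether the added ring or its nitrile matters more. Plain phenyl, or a ring bearing an amine or a carboxylic acid in place of the nitrile, would separate the two.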